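Removing One Trifluoromethyl from a Urea Aryl Ring

The compounds below may be only part of what the source reports. "The series", "measured", "known", "first", "only" and "open" are said of these compounds alone.

Compound 1 `COc1cc(Cl)cc(-c2nn(-c3cccc(NC(=O)c4ccc(Cl)c(Cl)c4)c3)cc2-c2ccncc2)c1`: 63.2%
Compound 2 `O=C(Nc1cccc(-n2cc(-c3ccncc3)c(-c3cc(O)cc(Cl)c3)n2)c1)Nc1ccc(Cl)c(Cl)c1`: -5.53%
Compound 3 `COc1cc(Cl)cc(-c2nn(-c3cccc(NC(=O)Nc4cc(C(F)(F)F)cc(C(F)(F)F)c4)c3)cc2-c2ccncc2)c1`: 6.56%

In a functional assay on T47D cells (Homo sapiens) for inhibition, read by sulforhodamine B assay, with a stated time of 48 h, tested at 10 uM (a higher number here means a weaker effect of the compound at the concentration tested, a lower number a stronger effect), compound 3 gives 6.56%, the second highest of the three numbers. Its nearest neighbour is compound 2, whose value lies lower by a gap beyond the usual scatter; compound 1 is furthest, well above it. Compound 4 `COc1cc(Cl)cc(-c2nn(-c3cccc(NC(=O)Nc4cccc(C(F)(F)F)c4)c3)cc2-c2ccncc2)c1` has not yet been measured in this assay. It differs from compound 3 in one place: hydrogen in place of trifluoromethyl on an aromatic carbon. Among the compounds with values here, no step between measured compounds tells how such a change acts here. The expected step from compound 3 to compound 4 is small, with no firm direction, and may sit within the scatter: a number 5.4 percentage points higher from compound 3 to compound 4 (within the scatter). Compound 4 is therefore estimated at 12%, within -12% to 40%.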

Compound 4, a percentage reported as activity, at one concentration (the size of the read-out at that concentration, not a potency): -0.45%
Estimate against measurement, compound 4: 12.5 percentage points above; low and high end bracket the measured number.
By their numbers in this assay, from the lowest: compounds 2, 4 and 3 (each within the scatter of the next, the first and the last beyond it); then compound 1.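

In this assay the step of a number 7 percentage points lower from compound 3 to compound 4 (within the scatter) shows that one trifluoromethyl on the urea aryl ring can be replaced by hydrogen without a change beyond the scatter. The step of a number 63.7 percentage points lower from compound 1 to compound 4 (beyond the scatter) is large and comes with (3-(trifluoromethyl)phenyl)amino in place of 3,4-dichlorophenyl on the carbonyl carbon. No measured evidence explains either step. The compounds shown leave open how an amine or a carboxylic acid in place of that trifluoromethyl would read in this assay.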